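Trading 4-Bromophenyl for Furan-2-yl in a Receptor Series

This account rests on a few compounds, and the source may have more. Where it says the series, first, only, none or still open, it means among the compounds named here.

Of the compounds shown here, two sharing one core have been measured. Compound 1 `Cc1nc(N)sc1CCCN/C(N)=N/C(=O)NC(C)c1ccc(Br)cc1` gives 30.2 nM in an assay on membranes from Sf9 cells for displacement of a labelled ligand from histamine H2 receptor (Homo sapiens), read by scintillation counting, with a stated time of 60 min; on this read-out higher numbers stand for weaker inhibition and lower numbers for stronger inhibition. Compound 2 `Cc1nc(N)sc1CCCN/C(N)=N/C(=O)NCC(C)CCCc1ccccc1` gives 60.3 nM in this assay. Compound 1 holds the lower of the two numbers, but the gap lies within the usual scatter, so nothing separates the pair with confidence. Compound 3 `Cc1nc(N)sc1CCCN/C(N)=N/C(=O)NC(C)c1ccco1` has not yet been measured in this assay. It differs from compound 1 in one place: furan-2-yl in place of 4-bromophenyl on a saturated chain carbon bound to an amide-type nitrogen and a saturated chain carbon. Going by the values given here, no step between measured compounds is available to anchor this change, so the expectation rests on the values of compound 1 and compound 2 alone. For compound 3 a modest weakening, at the edge of the scatter, is expected, a 2.6-fold higher number from compound 1 to compound 3 (0.42 log units; beyond the scatter). Compound 3 is accordingly estimated at 80 nM, within a range from 25 nM to 250 nM.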

Compound 3, inhibition constant: 31.6 nM
For compound 3 the middle estimate is 2.5-fold (0.40 log units) above the measured one; low and high end bracket the measured number.
By their numbers in this assay, from the lowest: compounds 1, 3 and 2 (each within the scatter of the next).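

Placing furan-2-yl in place of 4-bromophenyl on a saturated chain carbon bound to an amide-type nitrogen and a saturated chain carbon gives a 1.0-fold higher number from compound 1 to compound 3 (0.02 log units; within the scatter) in this assay and thus no separation between the two compounds. This first step at this position shows that the read-out does not distinguish a five-membered aromatic ring with 1 hetero atom from a six-membered aromatic ring of carbon only that carries bromine, even though the two groups differ in heavy atoms and hydrogen-bond acceptors. No measurement is available that would explain this match.

The compounds shown leave open how plain phenyl would read at this position, which would help to separate the contribution of the ring from that of the bromine. Going by these compounds, it also remains open whether the same match would hold for a cyclohexyl group, or for a ring carrying an amine or a carboxylic acid.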